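A few compounds are considered here, and "the series" means these few. Any claim that something is new, unique, unknown or untested is made for them only; others in the source may bear on it.

Among the measured compounds shown here, compound 3 `O=S(=O)(c1cn(C2CCCNC2)c2ncccc12)c1c(Cl)nc2sccn12` gives 0.708 nM in an assay on isolated protein for binding affinity to 5-hydroxytryptamine receptor 6 (Homo sapiens) (on this read-out lower numbers stand for stronger inhibition and higher numbers for weaker inhibition), the lowest of the three numbers measured so far, though neither of its neighbours lies beyond the scatter. Compound 1 `CN1CCC(n2cc(S(=O)(=O)c3c(Cl)nc4sccn34)c3cccnc32)C1` gives 0.794 nM in this assay, and compound 2 `CCN1CCC(n2cc(S(=O)(=O)c3c(Cl)nc4sccn34)c3cccnc32)C1` gives 1.41 nM. The steps between them are all small: a 1.1-fold lower number from compound 1 to compound 3 (0.05 log units; within the scatter), a 2.0-fold lower number from compound 2 to compound 3 (0.30 log units; within the scatter) and a 1.8-fold higher number from compound 1 to compound 2 (0.25 log units; within the scatter).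

Compound 4 `CC(C)N1CCCC(n2cc(S(=O)(=O)c3c(Cl)nc4sccn34)c3cccnc32)C1` differs from compound 3 by isopropyl in place of hydrogen on an amine nitrogen in a ring. For the measured compounds named here, no measured step puts an alkyl group onto the ring amine of the six-membered ring, so the nearest guide is the step of a 1.8-fold higher number from compound 1 to compound 2 (0.25 log units; within the scatter), where an added methyl on the amine-bound carbon of the five-membered ring left the number within the scatter. The swap of the whole ring-bearing group, a 2.0-fold lower number from compound 2 to compound 3 (0.30 log units; within the scatter), was likewise within the scatter. The account therefore expects the step of a 1.6-fold higher number from compound 3 to compound 4 (0.19 log units; within the scatter) to stay within the scatter, with any drift tending toward a slightly higher number, as was seen from compound 1 to compound 2. On that basis compound 4 is estimated at 1.1 nM in this assay, in a range from 0.35 nM to 3.5 nM.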

Compound 4, inhibition constant: 1.7 nM
Compound 4: the middle estimate sits 1.5-fold (0.19 log units) below what was measured; low and high end bracket the measured number.
By their numbers in this assay, from the lowest: compounds 3, 1, 2 and 4 (each within the scatter of the next, the first and the last beyond it).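

Isopropyl in place of hydrogen on an amine nitrogen in a ring of a six-membered non-aromatic ring gives, in this assay, a 2.4-fold higher number from compound 3 to compound 4 (0.38 log units; beyond the scatter), so, unlike the earlier steps, this one lies beyond the scatter, though it remains modest. The 1-isopropylpiperidin-3-yl group also separates from the 1-methylpyrrolidin-3-yl group, with a 2.1-fold higher number from compound 1 to compound 4 (0.33 log units; beyond the scatter), while against the 1-ethylpyrrolidin-3-yl group it does not, with a 1.2-fold higher number from compound 2 to compound 4 (0.08 log units; within the scatter); this position therefore tolerates isopropyl with only a modest shift in the number. The data on hand offer no measurement that would account for this shift.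

The compounds shown leave open whether methyl or ethyl on this amine nitrogen would give a step as large as isopropyl does, or whether the number would keep rising with a longer chain such as n-butyl or with a benzyl group. They also leave open whether an acetyl group on the same nitrogen, which would turn the amine into an amide, would stay near these numbers.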